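The source may hold more compounds than are shown below. What is called first, only, known or untested is meant among the compounds shown, and "the series" means these compounds.

Compound 1 `C/N=C(/NC#N)NCCCn1nc(-c2ccccc2)ccc1=O`: in a functional assay on the whole organism with Rattus norvegicus as the target, at a dose of 100 mg/kg (a lower number here means less inhibition, a higher number more inhibition at the dose given (going by the name of the read-out)), compound 1 gives 40.5%.
Compound 2 `N#CNC(=N)NCCCCCn1nc(-c2ccccc2)ccc1=O`: compound 2 gives 31%.
Compound 3 `CCC/N=C(/NC#N)NCCCn1nc(-c2ccccc2)ccc1=O`: compound 3 gives 52.9%.

Compound 3 stands highest of the three numbers; its nearest neighbour is compound 1, and the gap a number 12.4 percentage points higher from compound 1 to compound 3 (beyond the scatter) lies beyond the scatter, as does its gap to compound 2. Compound 4 `CC/N=C(\S)NCCCn1nc(-c2ccccc2)ccc1=O` has not yet been measured. It differs from compound 3 in one place: a group of 5 heavy atoms (3 carbon, 1 nitrogen, 1 sulfur; no ring) in place of a group of 8 heavy atoms (5 carbon, 3 nitrogen; no ring), on an amine nitrogen.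

Within the data shown here, two measured steps touch the same region of the molecule. The step of a number 12.4 percentage points higher from compound 1 to compound 3 (beyond the scatter) is the only one that moved the read-out beyond the scatter, and it concerns the same side chain that is rebuilt here. The step of a number 9.5 percentage points lower from compound 1 to compound 2 (within the scatter) also rebuilt this group, and stayed within the scatter. Among the measured compounds shown here, neither is the same change as the one to compound 4, so the direction is not fixed by the data. Since the two earlier changes in this part gave at most a modest movement, the expected step of a number 9.9 percentage points lower from compound 3 to compound 4 (within the scatter) is one that does not clearly exceed the scatter, leaning downward. Compound 4 is therefore expected to give about 43%, with a plausible range from 26% to 60%.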

Compound 4, a percentage reported as inhibition, in the whole organism at one dose (the size of the read-out at that dose, not a potency): 39%
Compound 4: the middle estimate sits 4 percentage points above what was measured, and the stated range covers the measured number.
By their numbers in this assay, from the lowest: compounds 2, 4 and 1 (each within the scatter of the next); then compound 3.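

In this assay, the sulfur-bearing group of compound 4, placed on the amine nitrogen, does not hold the level set by the larger group it replaces: the change is a number 13.9 percentage points lower from compound 3 to compound 4 (beyond the scatter). Set against the smaller group of compound 1, the same position gives a number 1.5 percentage points lower from compound 1 to compound 4 (within the scatter), and the comparison with the longer-chain compound 2 gives a number 8 percentage points higher from compound 2 to compound 4 (within the scatter), so both of these steps leave compound 4 level with its partner, and among the compounds shown only compound 3 stands clear of the others. Among these compounds, this means that a rebuilt group at this position can leave the read-out unchanged, and that the ethyl gain from a number 12.4 percentage points higher from compound 1 to compound 3 (beyond the scatter) belongs so far to the cyano-bearing group alone and has no counterpart in the sulfur-bearing series. No measurement given here bears on why the read-out moved.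

Still open, on these data alone, is whether a urea in place of the sulfur-bearing group, or a butyl chain in place of its ethyl, would bring the number back towards that of compound 3. With a single dose, these numbers also say nothing about how the compounds would compare at other doses.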